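Phenoxy to Thiophene Ethoxy: Cytotoxicity Stays at the Limit

This account rests on a few compounds, and the source may have more. Where it says the series, first, only, none or still open, it means among the compounds named here.

Compound 2 `Cc1nc(C)c([C@H](OC(C)(C)C)C(=O)O)c(N2CCC(C)(C)CC2)c1-c1ccc(Oc2ccccc2)cc1` is the point of departure. In a toxicity assay on MT2 cells (Homo sapiens) for cytotoxicity, read by XTT assay, with a stated time of 4 days (a higher number here means that more compound is tolerated, a lower number that less compound is tolerated), compound 2 reaches only a limit of the assay, >= 20000 nM. Its neighbour compound 1 `Cc1nc(C)c([C@H](OC(C)(C)C)C(=O)O)c(N2CCC(C)(C)CC2)c1-c1ccc(-c2ccccc2)cc1` likewise reaches only a limit, >= 20000 nM, so the step that the two limits leave unreadable from compound 1 to compound 2 cannot be read; both sit at the limit of >= 20000 nM in this assay, at which 2 of the 3 values shown sit. Compound 3 `Cc1nc(C)c([C@H](OC(C)(C)C)C(=O)O)c(N2CCC(C)(C)CC2)c1-c1ccc(OC2CCCC2c2ccc(F)cc2)cc1` also reaches only limits, >= 32000 nM; >= 32000 nM (2 entries). Among the three compounds no numbered value exists, and compound 2 stands level with them at the limit.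

Compound 4 `Cc1ccc(CCOc2ccc(-c3c(C)nc(C)c([C@H](OC(C)(C)C)C(=O)O)c3N3CCC(C)(C)CC3)cc2)s1` carries the change (2-(5-methylthiophen-2-yl)ethyl in place of phenyl on an oxygen on an aromatic ring). Going by the values given here, no measured step gives its size, so a result at the limit is expected again. For compound 4 the estimated value in this assay is 20000 nM, between 10000 nM and 40000 nM, which is expected to mean a step of a number no higher from compound 2 to compound 4 (the limit leaves the size open) within the scatter.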

Compound 4, half-maximal cytotoxic concentration: >= 25000 nM
Compound 4: only a limit was reported (the forecaster's own chance of this, stated with the estimate: 85%); at least 1.2-fold (0.09 log units) between middle value and limit.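

In this assay compound 4 gives only a limit, >= 25000 nM, so the steps to it from compound 1 and compound 2 cannot be read. The compounds shown leave open whether any of these changes shifts the half-maximal cytotoxic concentration at all: none carries a numbered value.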